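Ortho chloro on the benzamide of the sulfonamide series

A few compounds are considered here, and "the series" means these few. Any claim that something is new, unique, unknown or untested is made for them only; others in the source may bear on it.

Compound 1 `COc1ccc(-c2cccc(C(=O)N(C)C)c2)cc1S(=O)(=O)Nc1cccc(NCCNC(=O)c2ccccc2)c1` is the unsubstituted benzamide of the series. In a functional assay on CHO-K1 cells for agonist activity at Orexin receptor type 2 (Homo sapiens), read by calcium flux (a lower number here means a smaller maximal response, a higher number a larger maximal response), compound 1 is reported as "not active" (no number reported), with no single number, so it has no measured place among the others. Compound 2 `COc1cccc(C(=O)NCCNc2cccc(NS(=O)(=O)c3cc(-c4cccc(C(=O)N(C)C)c4)ccc3OC)c2)c1` gives 54% and compound 3 `COc1ccc(-c2cccc(C(=O)N(C)C)c2)cc1S(=O)(=O)Nc1cccc(NCCNC(=O)c2ccccc2C)c1` gives 85%. The step of a number 31 percentage points higher from compound 2 to compound 3 (beyond the scatter) shows that the aryl group on the carbonyl carbon moves the maximal response strongly. Compound 4 `COc1ccc(-c2cccc(C(=O)N(C)C)c2)cc1S(=O)(=O)Nc1cccc(NCCNC(=O)c2ccccc2Cl)c1` differs from compound 1 by chloro in place of hydrogen on an aromatic carbon ortho to a large group. Among the compounds with values here, no step links compound 1 to compound 4, but compound 3 also carries its substituent on an aromatic carbon ortho to a large group and reaches 85%; a clear response from an inactive starting point is therefore expected. Compound 4 is estimated at 70%, range 40% to 95%.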

Compound 4, largest response reached (Emax), in percent of the reference or control that the assay uses: 90%
For compound 4 the middle estimate is 20 percentage points below the measured one; measured number inside the range.
By their numbers in this assay, from the lowest: compound 2; then compounds 3 and 4 (each within the scatter of the next).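

In this assay, chloro and methyl on an aromatic carbon ortho to a large group are not separated, with a number 5 percentage points higher from compound 3 to compound 4 (within the scatter). The 2-chlorophenyl group shares the clear gain over 3-methoxyphenyl, giving a number 36 percentage points higher from compound 2 to compound 4 (beyond the scatter), so two different small groups at this place now give a response, whereas compound 1, with hydrogen, is reported as "not active" (no number reported). No measurement at hand accounts for these differences. Going by these compounds, whether fluoro, an amine or a carboxylic acid on this carbon would also give a response stays open. So does how far the response of compound 4 depends on the rest of the chain.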